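The compounds below may be only part of what the source reports. "The series", "measured", "known", "first", "only" and "open" are said of these compounds alone.

In a functional assay on HCT-116 cells (Homo sapiens) for cytotoxicity, read by MTT assay, with a stated time of 3 days (on this read-out higher numbers stand for weaker inhibition and lower numbers for stronger inhibition), compound 1 `CC(C)(C)c1cc2c(N/N=C/c3ccc(CN)cc3)ncnc2s1` gives 0.334 ug/mL. Going by the values given here, this is the higher of the two numbers so far, since compound 2 `CN1Cc2ccc(/C=N/Nc3ncnc4sc(C(C)(C)C)cc34)cc2C1` gives 0.088 ug/mL, and the gap lies beyond the usual scatter. Compound 3 `CN(C)S(=O)(=O)c1ccc(/C=N/Nc2ncnc3sc(C(C)(C)C)cc23)cc1` keeps the shared core of compound 1 but swaps one group: dimethylsulfamoyl in place of aminomethyl on an aromatic carbon. Among the compounds with values here, no measured pair shows this swap, so the expectation is loose. In this assay, a modest expected step towards weaker inhibition, a 2.4-fold higher number from compound 1 to compound 3 (0.38 log units; beyond the scatter), seems most likely. For compound 3 the estimated value is 0.8 ug/mL, with an expected range from 0.2 ug/mL to 3 ug/mL.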

Compound 3, half-maximal inhibitory concentration: 1.42 ug/mL
Compound 3: middle estimate off by 1.8-fold (0.25 log units), on the low side; measured number inside the range.
By their numbers in this assay, from the lowest: compound 2; then compound 1; then compound 3.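

In this assay, dimethylsulfamoyl in place of aminomethyl on the aromatic carbon gives a 4.3-fold higher number from compound 1 to compound 3 (0.63 log units; beyond the scatter), so what sits at this place para to a large group does change the read-out. Here the group that enters has more heavy atoms and no hydrogen-bond donor, and it goes with weaker inhibition, but this single pair cannot separate those two differences. No measurement at hand explains the step. The compounds shown leave open how a carboxylic acid, a simple methoxy group or a longer aminoalkyl chain at this place would compare.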